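Urea substituent series on the shared core: compound 4

The source may hold more compounds than are shown below. What is called first, only, known or untested is meant among the compounds shown, and "the series" means these compounds.

Within the data shown here, in a functional assay on Shh Light II cells (Mus musculus) for inhibition, read by a luciferase reporter (on this read-out lower numbers stand for stronger inhibition and higher numbers for weaker inhibition), compound 3 `O=C(Nc1ccccc1Cl)N1CCC(c2nc(-c3ccc4ccccc4n3)no2)CC1` gives 510 nM, the second highest of the three numbers so far. Compound 1 `O=C(NC1CC[S+]([O-])CC1)N1CCC(c2nc(-c3ccc4ccccc4n3)no2)CC1` gives 850 nM and compound 2 `N#Cc1ccccc1NC(=O)N1CCC(c2nc(-c3ccc4ccccc4n3)no2)CC1` gives 190 nM. The step of a 1.7-fold lower number from compound 1 to compound 3 (0.22 log units; within the scatter) lies within the scatter, whereas a 4.5-fold lower number from compound 1 to compound 2 (0.65 log units; beyond the scatter) and a 2.7-fold higher number from compound 2 to compound 3 (0.43 log units; beyond the scatter) lie beyond it. Compound 4 `O=C(NC1CCNCC1)N1CCC(c2nc(-c3ccc4ccccc4n3)no2)CC1` differs from compound 3 by piperidin-4-yl in place of 2-chlorophenyl on an amide-type nitrogen. The step of a 1.7-fold lower number from compound 1 to compound 3 (0.22 log units; within the scatter) bears most directly on this: there a six-membered non-aromatic ring with 1 hetero atom gave way to 2-chlorophenyl on the same amide-type nitrogen, and the change now runs the other way. Compound 4 is expected to show a 1.8-fold higher number from compound 3 to compound 4 (0.25 log units; within the scatter), because a 1.7-fold lower number from compound 1 to compound 3 (0.22 log units; within the scatter) stayed within the scatter. The estimate for compound 4 is 900 nM, with a range of 350 nM to 2500 nM.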

Compound 4, half-maximal inhibitory concentration: 2500 nM
For compound 4 the middle estimate is 2.8-fold (0.44 log units) below the measured one, within the range that was stated.
By their numbers in this assay, from the lowest: compound 2; then compounds 3 and 1 (each within the scatter of the next); then compound 4.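

In this assay, piperidin-4-yl on this amide-type nitrogen gives the weakest compound of the four, with a 4.9-fold higher number from compound 3 to compound 4 (0.69 log units; beyond the scatter) and a 2.9-fold higher number from compound 1 to compound 4 (0.47 log units; beyond the scatter). Set against 2-cyanophenyl, the change gives a 13-fold higher number from compound 2 to compound 4 (1.12 log units; beyond the scatter), the largest step in the series so far, and it shows that non-aromatic rings at this position are not equivalent to one another. Nothing at hand accounts for these differences. Open, on these data alone, is whether the ring nitrogen of piperidin-4-yl drives the loss, which a cyclohexyl or tetrahydropyran-4-yl group on the same urea nitrogen would test.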